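This account rests on a few compounds, and the source may have more. Where it says the series, first, only, none or still open, it means among the compounds named here.

In a functional assay on MKN-45 cells (Homo sapiens) for inhibition, read by CCK-8 assay, with a stated time of 24 h (a lower number here means a stronger inhibitor, a higher number a weaker inhibitor), the measured compounds read:

- Compound 1 `Cc1ccccc1-n1cc(-c2ccc(/C=C3\C(=O)Nc4ccccc43)cc2)nn1`: 9770 nM
- Compound 2 `O=C1Nc2ccccc2/C1=C/c1ccc(-c2cn(-c3ccc(F)cc3)nn2)cc1`: 16700 nM
- Compound 3 `O=C1Nc2ccccc2/C1=C/c1ccc(-c2cn(-c3ccccc3Cl)nn2)cc1`: > 20000 nM

Compound 3 stands at > 20000 nM, which is a limit of this assay and not a number. Compound 4 `O=C1Nc2ccccc2/C1=C/c1ccc(-c2cn(-c3ccc(Cl)cc3)nn2)cc1` has 4-chlorophenyl in place of 2-chlorophenyl on an aromatic nitrogen. The closest evidence is an at least 1.1-fold higher number from compound 2 to compound 3 (0.07 log units; that floor lies within the scatter), where 2-chlorophenyl replaced 4-fluorophenyl. Also relevant is a 1.7-fold higher number from compound 1 to compound 2 (0.23 log units; within the scatter). Compound 2, with its 4-fluorophenyl group at 16700 nM, suggests that compound 4 should read close to it. A modest move to a lower number is therefore expected, perhaps little beyond the scatter. The expected step is an at least 1.3-fold lower number from compound 3 to compound 4 (0.12 log units; that floor lies within the scatter). For compound 4 the estimate is 15000 nM, with an expected range of 7000 nM to 25000 nM.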

Compound 4, half-maximal inhibitory concentration: 16200 nM
The estimate for compound 4 lay 1.1-fold (0.03 log units) below the measured number; low and high end bracket the measured number.
By their numbers in this assay, from the lowest: compounds 1, 4 and 2 (each within the scatter of the next). At a limit, above all of these: compound 3.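

In this assay, 4-chlorophenyl in place of 2-chlorophenyl gives an at least 1.2-fold lower number from compound 3 to compound 4 (0.09 log units; that floor lies within the scatter), a floor only, because compound 3 stands at a limit and not a number: the limit of > 20000 nM in this assay, at which 1 of the 4 values shown sits.

Chloro in place of fluoro gives a 1.0-fold lower number from compound 2 to compound 4 (0.01 log units; within the scatter), and 4-chlorophenyl in place of 2-methylphenyl gives a 1.7-fold higher number from compound 1 to compound 4 (0.22 log units; within the scatter), so neither change separates these compounds in this read-out.

The compounds shown leave open whether an amine or a carboxylic acid on this phenyl ring would read differently from chloro and fluoro.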